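Amide-nitrogen substituent series: cyclopropyl replaces isopropyl

A few compounds are considered here, and "the series" means these few. Any claim that something is new, unique, unknown or untested is made for them only; others in the source may bear on it.

The shared core carries a fused two-ring system with a six-membered non-aromatic ring of one nitrogen and one oxygen, and the compounds differ in what sits on that amide-type nitrogen. Compound 1 `Cc1ccc(N2C(=O)COc3ccc(-c4cnc5ccccc5c4)cc32)cc1` is measured in a functional assay on HepG2 cells (Homo sapiens) for antiproliferative activity, read by MTT assay, with a stated time of 72 h; a lower number here means a stronger inhibitor, a higher number a weaker inhibitor; compound 1 gives only a limit, > 40000 nM. Compound 2 `O=C1COc2ccc(-c3cnc(Cl)c(NS(=O)(=O)c4ccc(F)cc4)c3)cc2N1C1CCCCC1` likewise gives a limit in this assay, > 40000 nM. Among the compounds with values here, compound 3 `CC(C)N1C(=O)COc2ccc(-c3cnc(Cl)c(NS(=O)(=O)c4ccc(F)cc4)c3)cc21` is the only compound of the three with a number, 21500 nM in this assay. Within the data shown here, the one step between neighbours, an at least 1.8-fold lower number from compound 2 to compound 3 (0.26 log units; that floor lies within the scatter), carries isopropyl in place of cyclohexyl, and its floor is set by the limit of > 40000 nM in this assay, at which 2 of the 3 values shown sit.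

Compound 4 `O=C1COc2ccc(-c3cnc(Cl)c(NS(=O)(=O)c4ccc(F)cc4)c3)cc2N1C1CC1` is not yet measured. Its change from compound 3 is cyclopropyl in place of isopropyl on an amide-type nitrogen in a ring. Among the measured compounds shown here, the only step on this nitrogen gave at least a small move, so a step of similar modest size or none beyond the scatter is expected, with the floor of the scale leaving the direction open. For compound 4 a value of 20000 nM is estimated, between 8000 nM and 50000 nM, which is expected to mean a 1.1-fold lower number from compound 3 to compound 4 (0.03 log units; within the scatter).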

Compound 4, half-maximal inhibitory concentration: 8510 nM
The estimate for compound 4 lay 2.4-fold (0.37 log units) above the measured number, within the range that was stated.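

Within the data shown here, on the amide-type nitrogen, cyclopropyl in place of isopropyl gives a 2.5-fold lower number from compound 3 to compound 4 (0.40 log units; beyond the scatter) in this assay, the first step at this position with a measured number at both ends and a size beyond the scatter. Both groups have the same heavy-atom count, so this nitrogen responds to a change from open branched group to three-membered ring without any added heavy atoms. Compound 4 also separates clearly from the cyclohexyl compound, with an at least 4.7-fold lower number from compound 2 to compound 4 (0.67 log units; beyond the scatter), though that size is only a floor set by a limit: the limit of > 40000 nM in this assay, at which 2 of the 4 values shown sit.

The compounds shown do not tell whether ring size alone orders these values, and cyclobutyl or cyclopentyl on this nitrogen would test that. Nor do they show how an unbranched chain such as ethyl, or a longer chain ending in an amine, would compare with cyclopropyl here.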